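Cyano for chloro on a diarylthiourea: cytotoxicity expectation

The compounds below may be only part of what the source reports. "The series", "measured", "known", "first", "only" and "open" are said of these compounds alone.

In an ADME assay on BHK cells (Mesocricetus auratus) for cytotoxicity, read by MTT assay, with a stated time of 96 h (a higher number here means that more compound is tolerated, a lower number that less compound is tolerated), compound 2 `FC(F)(F)c1cccc(NC(=S)Nc2ccc(Cl)cc2)c1` gives 10000 nM, level with compound 1 `FC(F)(F)c1cccc(NC(=S)Nc2cccc(Br)c2)c1`, which gives 10000 nM. The step of no change at the digits printed from compound 1 to compound 2 (within the scatter) stays within the scatter. Compound 3 `CC(=O)NC(=S)Nc1cccc(C(F)(F)F)c1` reports only > 100000 nM, a limit of the assay, sitting at the limit of > 100000 nM in this assay, at which 1 of the 3 values shown sits. The steps of an at least 10-fold higher number from compound 1 to compound 3 (1.00 log units; beyond the scatter) and an at least 10-fold higher number from compound 2 to compound 3 (1.00 log units; beyond the scatter) are the only ones beyond the scatter, and both replace an aryl group by acetyl on the amide-type nitrogen. Compound 4 `N#Cc1ccc(NC(=S)Nc2cccc(C(F)(F)F)c2)cc1` differs from compound 2 by cyano in place of chloro on an aromatic carbon. Among the compounds with values here, no measured step exchanges one aryl substituent for cyano; the halogen exchange between compound 1 and compound 2 left the number unchanged. The chemist therefore expects for compound 4 in this assay a step of no change at the digits printed from compound 2 to compound 4 (within the scatter), nothing beyond the scatter. The estimate for compound 4 is 10000 nM, ranging from 4000 nM to 25000 nM.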

Compound 4, half-maximal cytotoxic concentration: 9500 nM
Compound 4: middle estimate off by 1.1-fold (0.02 log units), on the high side; measured number inside the range.
By their numbers in this assay, from the lowest: compounds 4, 1 and 2 (each within the scatter of the next). At a limit, above all of these: compound 3.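

Cyano in place of chloro, on an aromatic carbon para to a large group, gives in this assay a 1.1-fold lower number from compound 2 to compound 4 (0.02 log units; within the scatter). The earlier compounds had shown only an exchange between halogen-bearing aryl groups; this step shows that a substituent without halogen, bringing a triple bond and a hydrogen-bond acceptor, also leaves the number within the scatter at this position. Nothing measured here explains why the number holds. As far as these compounds go, whether an amine or a carboxylic acid at this position would keep the number there remains open.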